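Quinolin-8-yl sulfonamide estimated from a benzofurazan analogue

The source may report more compounds than this note shows. Statements on the series, on what has been measured and on what is new or still open speak of the compounds shown alone.

Three sulfonamides sharing one core have been measured in an assay on HEK293 cells for displacement of a labelled ligand from 5-hydroxytryptamine receptor 6 (Homo sapiens); on this read-out higher numbers stand for weaker inhibition and lower numbers for stronger inhibition. Compound 1 `O=S(=O)(c1ccccc1Cl)N1CCOc2c(N3CCNCC3)cccc21` gives 3.16 nM. Compound 2 `O=S(=O)(c1cccc2ccccc12)N1CCOc2c(N3CCNCC3)cc(Cl)cc21` gives 0.794 nM, and compound 3 `O=S(=O)(c1cccc2nonc12)N1CCOc2c(N3CCNCC3)cc(Cl)cc21` gives 0.501 nM. Compound 3 thus shows the lowest of the three numbers: the gap from compound 1 lies beyond the scatter, whereas the gap to compound 2 lies within the scatter.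

Within the data shown here, the single step that bears directly on the sulfonyl substituent is a 1.6-fold lower number from compound 2 to compound 3 (0.20 log units; within the scatter), a change that stayed within the scatter. Compound 4 `O=S(=O)(c1cccc2cccnc12)N1CCOc2c(N3CCNCC3)cc(Cl)cc21` is obtained from compound 3 by a group of 10 heavy atoms (9 carbon, 1 nitrogen; one six-membered aromatic ring of carbon only, one six-membered aromatic ring with 1 hetero atom) in place of a group of 9 heavy atoms (6 carbon, 2 nitrogen, 1 oxygen; one five-membered aromatic ring with 3 hetero atoms, one six-membered aromatic ring of carbon only), on a sulfonyl sulfur. Since the earlier swap of one bicyclic aryl for another on the same sulfonyl sulfur moved the number only within the scatter, the swap to quinolin-8-yl is expected to produce no step beyond the scatter in this assay, expressed as a 1.4-fold higher number from compound 3 to compound 4 (0.15 log units; within the scatter). For compound 4 the estimate is therefore 0.7 nM, with a range from 0.3 nM to 1.8 nM.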

Compound 4, inhibition constant: 0.631 nM
Beside the measured number, compound 4's estimate is 1.1-fold (0.05 log units) above it, within the range that was stated.
By their numbers in this assay, from the lowest: compounds 3, 4 and 2 (each within the scatter of the next); then compound 1.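

In this assay, quinolin-8-yl on the sulfonyl sulfur gives a 1.3-fold higher number from compound 3 to compound 4 (0.10 log units; within the scatter), and the direct exchange for naphthalen-1-yl gives a 1.3-fold lower number from compound 2 to compound 4 (0.10 log units; within the scatter). Among these compounds, the earlier compounds offered only one such comparison, whereas compounds 2, 3 and 4 now all lie within the scatter of one another, so three different bicyclic aryl groups on this sulfur, including a carbon-only pair of rings and a pair with one ring nitrogen, cannot be told apart on this read-out. Nothing available here explains this likeness.

On these data alone, it remains open whether a plain alkyl group such as methyl or n-butyl on the sulfonyl sulfur would fall within the same scatter. Also open, as far as these compounds go, is what the aryl group of compound 1 would give on the core shared by compounds 2, 3 and 4.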